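The source may report more compounds than this note shows. Statements on the series, on what has been measured and on what is new or still open speak of the compounds shown alone.

Among the measured compounds shown here, in a physicochemical assay for lipophilicity, measured as octanol-water partition (a higher number here means a more lipophilic compound, a lower number a more polar compound), compound 1 `O=C(COc1cccc2ccccc12)N/N=C/c1ccc(Cl)cc1` gives 4.54 as the highest number of the three measured so far. Compound 2 `O=C(COc1cccc2ccccc12)N/N=C/c1ccc(O)cc1` gives 3.73 and compound 3 `O=C(COc1cccc2ccccc12)N/N=C/c1ccccc1O` gives 3.73 at the low end of the series, level with compound 2 and well under compound 1.

The next compound is compound 4 `O=C(COc1cccc2ccccc12)N/N=C/c1ccccc1Cl`, still unmeasured. It differs from compound 3 by chloro in place of hydroxy on an aromatic carbon in the form of chloro in place of hydroxy on an aromatic carbon, ortho to a large group.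

For the measured compounds named here, two measured steps bear on this change, both modest and both running the other way. One is a number 0.81 log units lower from compound 1 to compound 2 (beyond the scatter) with hydroxy in place of chloro on an aromatic carbon. The other is a number 0.81 log units lower from compound 1 to compound 3 (beyond the scatter) with 2-hydroxyphenyl in place of 4-chlorophenyl on a carbon with a double bond to nitrogen. Between the two hydroxy compounds there is no change at the digits printed from compound 2 to compound 3 (within the scatter) so the 2-hydroxyphenyl and 4-hydroxyphenyl forms read alike here. Going by the values given here, no measured compound carries 2-chlorophenyl, so the comparison with 4-chlorophenyl remains indirect.

Reading those steps in reverse, a modest rise is expected, estimated as a number 0.77 log units higher from compound 3 to compound 4 (beyond the scatter) in this assay and beyond the scatter. Compound 4 is estimated at 4.5 with 4.2 to 4.8 as its expected range.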

Compound 4, partition coefficient: 4.54
For compound 4 the middle estimate is 0.04 log units below the measured one; the range from low to high includes it.
By their numbers in this assay, from the lowest: compounds 2 and 3 (each within the scatter of the next); then compounds 1 and 4 (each within the scatter of the next).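

On an aromatic carbon ortho to a large group, chloro in place of hydroxy now has a direct reading in this assay: the step is a number 0.81 log units higher from compound 3 to compound 4 (beyond the scatter), which matches in size the change seen earlier between the 4-chlorophenyl and 4-hydroxyphenyl forms. The 2-chlorophenyl form shows a number 0.81 log units higher from compound 2 to compound 4 (beyond the scatter) when set against the 4-hydroxyphenyl form, but no change at the digits printed from compound 1 to compound 4 (within the scatter) when set against the 4-chlorophenyl form, so the two chloro forms read alike here, just as the two hydroxy forms did, and the identity of the group carries the difference across these four compounds. No measurement offered alongside these numbers accounts for the result.

The compounds shown carry only chloro and hydroxy on this ring, so it remains open whether a methoxy group, an amine or a carboxylic acid at the same place would also read alike in both placements. Going by these compounds, it is equally open whether the same step would appear on a core other than the one shared here.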